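The source may hold more compounds than are shown below. What is called first, only, known or untested is meant among the compounds shown, and "the series" means these compounds.

Measured compounds:
Compound 1, `Cc1ccc(Oc2ccc3nc(COc4cccc(C(=O)O)c4)n(C)c3n2)cc1C`, gives 12.4 10^-6 cm/s.
Compound 2, `Cn1c(COc2cccc(C(=O)O)c2)nc2cnc(Oc3ccc4c(c3)CCC4)cc21`, gives 16.5 10^-6 cm/s.
Compound 3, `Cn1c(COc2cccc(C(=O)O)c2)nc2ccc(Oc3cc(Cl)ccn3)cc21`, gives 10.3 10^-6 cm/s.

These values come from an ADME assay for permeability, using PAMPA, with a stated time of 4 h; a lower number here means that the compound crosses the layer more slowly, a higher number that the compound crosses the layer faster. The three numbers differ from one another by less than the usual scatter of repeated measurements, so compound 3 is not set apart from compound 1 or compound 2 by these data. Compound 4, `Cc1ccc(C)c(Oc2ccc3nc(COc4cccc(C(=O)O)c4)n(C)c3c2)n1`, has not yet been measured. It differs from compound 3 in one place: 3,6-dimethylpyridin-2-yl in place of 4-chloropyridin-2-yl on an oxygen on an aromatic ring. Within the data shown here, no pair of measured compounds differing in a single place is available, so the size of such a step cannot be read from earlier pairs. Compound 1, compound 2 and compound 3 carry different groups on that oxygen yet give similar numbers, so only a small step is expected here, a 1.2-fold higher number from compound 3 to compound 4 (0.07 log units; within the scatter). Compound 4 is estimated at 12 10^-6 cm/s, expected to fall between 7 10^-6 cm/s and 22 10^-6 cm/s.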

Compound 4, apparent permeability: 11 10^-6 cm/s
Compound 4: the middle estimate sits 1.1-fold (0.04 log units) above what was measured; the range from low to high includes it.
By their numbers in this assay, from the lowest: compounds 3, 4, 1 and 2 (each within the scatter of the next).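

In this assay, among these compounds, 3,6-dimethylpyridin-2-yl in place of 4-chloropyridin-2-yl on an oxygen on an aromatic ring gives a 1.1-fold higher number from compound 3 to compound 4 (0.03 log units; within the scatter), the first direct comparison in which only this group differs. With the core held constant, this one exchange of pyridine substituents leaves the read-out within the scatter. Nothing measured here gives a reason for this result. Both groups are aromatic rings with no net charge, so the step says little about very different groups. As far as these compounds go, whether an amine or a longer alkyl chain on that oxygen would also leave the number unchanged remains open.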